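A few compounds are considered here, and "the series" means these few. Any claim that something is new, unique, unknown or untested is made for them only; others in the source may bear on it.

In a functional assay on L1210 cells (Mus musculus) for inhibition (a higher number here means a weaker inhibitor, a lower number a stronger inhibitor), compound 1 `C#CCN(Cc1ccc2nc(C)nc(O)c2c1)c1ccccc1`, with hydrogen on the aromatic carbon, gives only a limit, > 6500 nM. Compound 2 `C#CCN(Cc1ccc2nc(C)nc(O)c2c1)c1ccc([N+](=O)[O-])cc1` reads 4700 nM and compound 3 `C#CCN(Cc1ccc2nc(C)nc(O)c2c1)c1ccc(S(N)(=O)=O)cc1` reads 20000 nM, the higher of these two numbers, with a 4.3-fold higher number from compound 2 to compound 3 (0.63 log units; beyond the scatter). Compound 4 `C#CCN(Cc1ccc2nc(C)nc(O)c2c1)c1ccc(S(=O)(=O)C(F)(F)F)cc1` differs from compound 3 by trifluoromethyl in place of amino on a sulfonyl sulfur. Among the measured compounds shown here, no measured step touches that sulfur directly. a step that the limit leaves unreadable from compound 1 to compound 3 cannot be sized, and an at least 1.3-fold lower number from compound 1 to compound 2 (0.14 log units; that floor lies within the scatter) gives only a floor. The sulfamoyl-for-nitro step is therefore the best guide, and a modest move back towards compound 2 at 4700 nM is expected. The expected change is a 3.3-fold lower number from compound 3 to compound 4 (0.52 log units; beyond the scatter). For compound 4 the estimated value is 6000 nM, with an expected range of 2000 nM to 18000 nM.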

Compound 4, half-maximal inhibitory concentration: 2750 nM
Compound 4: the middle estimate sits 2.2-fold (0.34 log units) above what was measured; low and high end bracket the measured number.
By their numbers in this assay, from the lowest: compounds 4 and 2 (each within the scatter of the next); then compound 3.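

In this assay, the change on the sulfonyl sulfur gives a 7.3-fold lower number from compound 3 to compound 4 (0.86 log units; beyond the scatter), so the higher number of compound 3 goes with its amino and not with the sulfonyl as such. Set against nitro, (trifluoromethyl)sulfonyl gives a 1.7-fold lower number from compound 2 to compound 4 (0.23 log units; within the scatter), so this assay does not separate these two groups. Set against hydrogen, it gives an at least 2.3-fold lower number from compound 1 to compound 4 (0.37 log units; beyond the scatter), the first step from that compound to clear the scatter, though it remains a floor: the limit of > 6500 nM in this assay, at which 1 of the 4 values shown sits.

As far as these compounds go, whether a methyl or a dimethylamino on that sulfur would read like compound 3 or compound 4 remains open.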